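This account rests on a few compounds, and the source may have more. Where it says the series, first, only, none or still open, it means among the compounds named here.

Of the compounds shown here, three of a shared core have been measured in a physicochemical assay for lipophilicity; a lower number here means a more polar compound, a higher number a more lipophilic compound. Compound 1, `C=C1CC[C@@H]2[C@](C)(CO[C@@H]3O[C@H](CO)[C@@H](O)[C@H](O)[C@H]3O)CCC[C@@]2(C)[C@@H]1CCC1=CCOC1=O`, carries a sugar on its core and gives 3.07. Compound 3, `C=C1CC[C@@H]2[C@](C)(CO)[C@H](O)CC[C@@]2(C)[C@@H]1CCC1=CCOC1=O`, carries two free hydroxyl groups and gives 3.43. Compound 2, `C=C1CC[C@@H]2[C@](C)(COC(C)=O)[C@H](OC(C)=O)CC[C@@]2(C)[C@@H]1C/C=C1\C=COC1=O`, carries two acetate groups and gives 3.87, the highest of the three numbers; its nearest neighbour is compound 3, whose number lies lower by an amount beyond the scatter, and its furthest is compound 1, lower still and also beyond the scatter.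

Compound 4, `C=C1CC[C@@H]2[C@](C)(COC(C)=O)[C@H](OC(C)=O)CC[C@@]2(C)[C@@H]1CCC1=CCOC1=O`, keeps both acetate groups of compound 2 and differs from it in one place: a group of 7 heavy atoms (5 carbon, 2 oxygen; one five-membered non-aromatic ring with 1 hetero atom) in place of a group of 7 heavy atoms (5 carbon, 2 oxygen; one five-membered non-aromatic ring with 1 hetero atom), on a saturated chain carbon bound to a saturated ring carbon. The group that leaves has one more double bond outside aromatic rings than the group that enters; in every other counted respect the two groups match, including the count of hydrogen-bond donors and acceptors.

Among the compounds with values here, no pair of measured compounds shows this exact change on its own, so the size of the step can only be guessed from the similarity of the two groups. With the same count of oxygen atoms and acceptors and the same ring on both sides, the step from compound 2 to compound 4 in this assay is expected to be small, a number 0.08 log units higher from compound 2 to compound 4 (within the scatter), lying within the scatter. Compound 4 is therefore estimated at 3.95, with a range from 3.55 to 4.35.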

Compound 4, partition coefficient: 4.02
Beside the measured number, compound 4's estimate is 0.07 log units below it; measured number inside the range.
By their numbers in this assay, from the lowest: compound 1; then compound 3; then compounds 2 and 4 (each within the scatter of the next).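

In this assay, taking one double bond outside aromatic rings away from the group on a saturated chain carbon bound to a saturated ring carbon, while the five-membered non-aromatic ring and the counts of hydrogen-bond donors and acceptors stay the same, gives a number 0.15 log units higher from compound 2 to compound 4 (within the scatter) and so leaves the two compounds indistinguishable in this measurement. Within the data shown here, this is the only step in the set that changes a single place, so it offers the only direct reading of this position: with both acetate groups held constant, this one difference in double bonds does not move the number beyond the scatter. No measurement shown here bears on why the step has this size.

Going by these compounds, whether the same change would give a similar step on a core carrying two free hydroxyl groups, as in compound 3, or a sugar, as in compound 1, remains open. Also open, on these data alone, is what a more different group at this place would do, such as an amine, a carboxylic acid or a longer chain in place of the five-membered ring.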